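The compounds below may be only part of what the source reports. "The series", "measured", "known", "first", "only" and "open" are said of these compounds alone.

Of the compounds shown here, two have been measured in a functional assay on T47D cells (Homo sapiens) for inhibition, read by sulforhodamine B assay, with a stated time of 48 h; on this read-out lower numbers stand for stronger inhibition of growth and higher numbers for weaker inhibition of growth. Compound 1 `O=C(/C(=C/C1CCCCC1)CCl)c1ccccc1` gives 29000 nM in this assay. Compound 2 `C=C(C/C(=C\c1ccccc1)C(=O)c1ccccc1)C(=O)c1ccccc1` differs from compound 1 in several places. In this assay compound 2 gives 15000 nM; the two numbers lie within the scatter of each other, so neither can be set apart from the other.

Compound 3 `C=C(C/C(=C\c1ccc(Cl)cc1)C(=O)c1ccccc1)C(=O)c1ccccc1` is the unmeasured partner of compound 2. The change from compound 2 to compound 3 is chloro in place of hydrogen on an aromatic carbon, para to a large group. Within the data shown here, no measured pair shows this change, so nothing in the data says how large its effect is. The step from compound 2 to compound 3 is therefore expected to be small, at most a modest lowering of the number, as a 1.5-fold lower number from compound 2 to compound 3 (0.18 log units; within the scatter). On that basis compound 3 is estimated to give 10000 nM in this assay, within a range from 4000 nM to 30000 nM.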

Compound 3, concentration for 50% growth inhibition: 19000 nM
Compound 3: middle estimate off by 1.9-fold (0.28 log units), on the low side, within the range that was stated.
By their numbers in this assay, from the lowest: compounds 2, 3 and 1 (each within the scatter of the next).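

Among these compounds, the change from phenyl to 4-chlorophenyl gives the first measured step at this position: in this assay, putting chloro in place of hydrogen, para to a large group, amounts to a 1.3-fold higher number from compound 2 to compound 3 (0.10 log units; within the scatter). On this single pair, then, a chlorine atom at this place leaves the read-out not separable from that of the unsubstituted phenyl, so this position tolerates the change without a step that can be told from scatter. Nothing measured here accounts for the size of this step.

Going by these compounds, whether another group at this place, such as an amine, a carboxylic acid or a methoxy group, would give a step beyond the scatter remains open. Also open, on these data alone, is whether chloro placed elsewhere in compound 2 would give a step of similar size.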